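The source may hold more compounds than are shown below. What is called first, only, known or untested is meant among the compounds shown, and "the series" means these compounds.

Of the compounds shown here, two that share a core have so far been measured in a functional assay on A549 cells (serum, Homo sapiens) for antiproliferative activity; a lower number here means a stronger inhibitor, a higher number a weaker inhibitor. In this test, compound 1 `Nc1nc(N)c2nc(CNc3ccc(C(=O)NC(CNC(=O)c4ccccc4C(=O)O)C(=O)O)cc3)cnc2n1` gives 23 nM and compound 2 `Nc1nc(N)c2nc(CNc3ccc(C(=O)NC(CCCNC(=O)c4cccc(C(=O)O)c4)C(=O)O)cc3)cnc2n1` gives 45 nM. These two values lie within the usual scatter of each other, so the numbers do not separate compound 2 from compound 1. Compound 3 `Nc1nc(N)c2nc(CNc3ccc(C(=O)NC(CCCNC(=O)c4ccc(C(=O)O)cc4)C(=O)O)cc3)cnc2n1` has the same atoms as compound 2, joined differently: 4-carboxyphenyl in place of 3-carboxyphenyl on a carbonyl carbon. In it, 4-carboxyphenyl takes the place of 3-carboxyphenyl on a carbonyl carbon whose other neighbours are amide-type nitrogen. Going by the values given here, no measured pair shows a step of this kind, so the data give no direct measure of its size. The expectation therefore rests on compound 2 at 45 nM, and no shift beyond the scatter is expected in this assay, in either direction. The estimated change is small, with a 1.1-fold lower number from compound 2 to compound 3 (0.05 log units; within the scatter) expected to stay within the scatter. Compound 3 is expected at 40 nM, with an estimated range of 13 nM to 125 nM.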

Compound 3, half-maximal inhibitory concentration: 3300 nM
Estimate against measurement, compound 3: 83-fold (1.92 log units) below; measured number above the stated range.
By their numbers in this assay, from the lowest: compounds 1 and 2 (each within the scatter of the next); then compound 3.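

In this assay, the change from 3-carboxyphenyl to 4-carboxyphenyl on a carbonyl carbon whose other neighbours are amide-type nitrogen gives a 73-fold higher number from compound 2 to compound 3 (1.87 log units; beyond the scatter), which lies well beyond the scatter. Going by these compounds alone, this is the first step that can be read, since compounds 1 and 2 differ in more than one place, and it shows that this site is highly sensitive to how the group is joined: the two groups have the same heavy atoms and the same counts of hydrogen-bond donors and acceptors. Nothing in the material at hand accounts for a step of this size.

The compounds shown leave open whether 2-carboxyphenyl on the chain of compounds 2 and 3 would stay in the range of compound 2 or fall away as compound 3 does, and whether the step would recur on the chain of compound 1. They also leave open whether a primary amide or a hydroxymethyl group in place of the carboxylic acid of 4-carboxyphenyl would change the number obtained in this assay.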